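This account rests on a few compounds, and the source may have more. Where it says the series, first, only, none or still open, it means among the compounds named here.

Compound 1 `COc1cc(-c2ccnc3cc(-c4cccc(C#N)c4)nn23)cc(OC)c1OC` stands at the limit of > 10000 nM in this assay, at which 1 of the 3 values shown sits; in a functional assay on HeLa cells (Homo sapiens) for inhibition, read by CCK-8 assay, with a stated time of 48 h (on this read-out lower numbers stand for stronger inhibition and higher numbers for weaker inhibition), compound 1 gives > 10000 nM, a limit rather than a number. In this assay compound 2 `C=Cc1ccc(-c2cc3nccc(-c4cc(OC)c(OC)c(OC)c4)n3n2)cc1` gives 882 nM, and compound 3 `COc1cc(-c2ccnc3cc(-c4cccc(C)c4)nn23)cc(OC)c1OC` gives 4230 nM. Both measured steps away from compound 1 lower the number: an at least 11-fold lower number from compound 1 to compound 2 (1.05 log units; beyond the scatter), and an at least 2.3-fold lower number from compound 1 to compound 3 (0.37 log units; beyond the scatter). Between the two replacement rings, a 4.8-fold higher number from compound 2 to compound 3 (0.68 log units; beyond the scatter). Compound 4 `COc1ccc(-c2cc3nccc(-c4cc(OC)c(OC)c(OC)c4)n3n2)cc1` differs from compound 1 in one place: 4-methoxyphenyl in place of 3-cyanophenyl on an aromatic carbon. Because an at least 11-fold lower number from compound 1 to compound 2 (1.05 log units; beyond the scatter) and an at least 2.3-fold lower number from compound 1 to compound 3 (0.37 log units; beyond the scatter) both bear on this change, a lower number is expected for compound 4, of a size between those two steps, an at least 6.6-fold lower number from compound 1 to compound 4 (0.82 log units; beyond the scatter). Compound 4 is therefore estimated at 1500 nM, with a range from 500 nM to 5000 nM.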

Compound 4, half-maximal inhibitory concentration: 373 nM
For compound 4 the middle estimate is 4.0-fold (0.60 log units) above the measured one; the measured number lies below the stated range.
By their numbers in this assay, from the lowest: compound 4; then compound 2; then compound 3. At a limit, above all of these: compound 1.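

The 4-methoxyphenyl group gives the lowest number yet at this position, with an 11-fold lower number from compound 3 to compound 4 (1.05 log units; beyond the scatter) and a 2.4-fold lower number from compound 2 to compound 4 (0.37 log units; beyond the scatter). The second of these steps shows that the group on the 4-position of the phenyl ring itself changes the number, since methoxy and vinyl are separated beyond the scatter. The widest step, an at least 26-fold lower number from compound 1 to compound 4 (1.42 log units; beyond the scatter), is only a bound: the limit of > 10000 nM in this assay, at which 1 of the 4 values shown sits.

The compounds shown leave open whether 4-ethoxyphenyl or 4-aminophenyl would go lower still. They also leave open how 3-methoxyphenyl would compare with 4-methoxyphenyl.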